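A few compounds are considered here, and "the series" means these few. Any claim that something is new, unique, unknown or untested is made for them only; others in the source may bear on it.

Working notes on the series. Compound 1 `CC(C)(C)NC(=O)NCCS(=O)(=O)NC(=O)c1ccc(Nc2nc(NC3(c4ccc(Cl)cc4)CC3)nc(OCC(F)(F)F)n2)cc1` gives 96% in an ADME assay on microsomes from liver (Homo sapiens) for metabolic stability, with a stated time of 10 min; on this read-out lower numbers stand for a less stable compound and higher numbers for a more stable compound. Compound 2 `CC(C)OC(=O)NCCS(=O)(=O)NC(=O)c1ccc(Nc2nc(NC3(c4ccc(Cl)cc4)CC3)nc(OCC(F)(F)F)n2)cc1` gives 100% in this assay; the only step shown so far, a number 4 percentage points higher from compound 1 to compound 2 (within the scatter), varies the group on the carbonyl carbon of the side chain and leaves the read-out where it was, so the two measured numbers do not separate, and compound 2 cannot be ranked against compound 1. Compound 3 `O=C(NS(=O)(=O)C1CC1)c1ccc(Nc2nc(NC3(c4ccc(Cl)cc4)CC3)nc(OCC(F)(F)F)n2)cc1` is not yet measured; the change from compound 2 is cyclopropyl in place of 2-((isopropoxycarbonyl)amino)ethyl on a sulfonyl sulfur, which removes the whole chain that carried the carbonyl varied in the measured step. That step bears only loosely on this one, as it lay within the scatter and touched a part of the group that now leaves. For the measured compounds named here, no measured step replaces a side chain of this size with a small ring. The expectation for compound 3 is therefore a step of a number 7 percentage points lower from compound 2 to compound 3 (within the scatter) not beyond the scatter, with the estimate 93% and range 78% to 100%.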

Compound 3, percent of the compound remaining: 100%
The estimate for compound 3 lay 7 percentage points below the measured number; low and high end bracket the measured number.
By their numbers in this assay, from the lowest: compounds 1, 2 and 3 (each within the scatter of the next).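

In this assay, the whole side chain on the sulfonyl sulfur can be exchanged for a small ring without a step beyond the scatter: no change at the digits printed from compound 2 to compound 3 (within the scatter), and a number 4 percentage points higher from compound 1 to compound 3 (within the scatter). The earlier step varied only the group on the carbonyl carbon, whereas these two steps remove the carbonyl, the chain and its hydrogen-bond donor altogether, and the read-out still does not separate the compounds. Nothing available explains this result.

All three compounds lie within the scatter of one another, so the series gives no ranking of the groups on the sulfonyl sulfur. As far as these compounds go, it remains open whether a phenyl ring, a primary amine or a carboxylic acid on a longer chain at this sulfur would stay within the scatter of compound 3 .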